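A few compounds are considered here, and "the series" means these few. Any claim that something is new, unique, unknown or untested is made for them only; others in the source may bear on it.

In an ADME assay on a cell-free system (plasma, Homo sapiens) for protein binding (a higher number here means a larger unbound share of the compound, a lower number a smaller unbound share), compound 1 `Cc1cc(NC(=O)Cn2nnc(-c3ccccc3)n2)n(C2CCCCC2)n1` gives 0.011 and compound 3 `Cc1cc(NC(=O)Cn2nnc(-c3ccccc3)n2)n(C2CCC(F)(F)CC2)n1` gives 0.015. Compound 2 `Cc1cc(NC(=S)Cn2nnc(-c3ccccc3)n2)n(C2CCCCC2)n1` returns only a limit, < 0.0006. Compound 4 `Cc1cc(NC(=O)Cn2nnc(-c3ccccc3)n2)n(C2CCS(=O)(=O)C2)n1` carries 1,1-dioxothiolan-3-yl in place of cyclohexyl on an aromatic nitrogen. For the measured compounds named here, the only measured change at this place is a 1.4-fold higher number from compound 1 to compound 3 (0.13 log units; within the scatter), so it offers no precedent for a step beyond the scatter. The entering group differs more, however, and has hydrogen-bond acceptors where cyclohexyl has none. A moderate rise in this assay is therefore expected, an estimated 4.5-fold higher number from compound 1 to compound 4 (0.66 log units; beyond the scatter). For compound 4 the expected value is 0.05, with an estimated range of 0.02 to 0.12.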

Compound 4, unbound fraction: 0.037
Compound 4: the middle estimate sits 1.4-fold (0.13 log units) above what was measured, within the range that was stated.
By their numbers in this assay, from the lowest: compounds 1 and 3 (each within the scatter of the next); then compound 4. At a limit, below all of these: compound 2.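

For the compounds shown here, at the aromatic nitrogen, 1,1-dioxothiolan-3-yl in place of cyclohexyl gives a 3.4-fold higher number from compound 1 to compound 4 (0.53 log units; beyond the scatter) in this assay and is the first change at this place that lies beyond the scatter. In place of 4,4-difluorocyclohexyl it gives a 2.5-fold higher number from compound 3 to compound 4 (0.39 log units; beyond the scatter) in the same read-out, so the rise holds against both groups. Nothing in the data shown accounts for this rise. The change alters ring size and ring atoms together, which leaves open which of them matters. Going by these compounds, an amine or a carboxylic acid on this cyclohexyl ring also remains open.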